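Adding a Third Methoxy Group to Compound 3

The source may report more compounds than this note shows. Statements on the series, on what has been measured and on what is new or still open speak of the compounds shown alone.

Growth inhibition was measured in a functional assay on MOLT-4 cells (Homo sapiens) for antiproliferative activity, with a stated time of 48 h (a lower number here means a stronger inhibitor of growth, a higher number a weaker inhibitor of growth), for three compounds:
compound 1, `Cc1cc(O)c(C2=NN(c3ccc(S(N)(=O)=O)cc3)C(c3ccccc3O)C2)cc1Cl`, gives 34400 nM;
compound 2, `Cc1cc(O)c(C2=NN(c3ccc(S(N)(=O)=O)cc3)C(c3ccccc3Cl)C2)cc1Cl`, gives 100000 nM;
compound 3, `COc1ccc(C2CC(c3cc(Cl)c(C)cc3O)=NN2c2ccc(S(N)(=O)=O)cc2)cc1OC`, gives 100000 nM.

Compound 3 sits at the weak end of these numbers. Its nearest neighbour is reached by no change at the digits printed from compound 2 to compound 3 (within the scatter), so the two cannot be told apart, and together they are the highest pair. The only clearly lower number belongs to compound 1, as shown by a 2.9-fold higher number from compound 1 to compound 3 (0.46 log units; beyond the scatter), a modest difference.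

Compound 4, `COc1ccc(C2CC(c3cc(Cl)c(C)cc3O)=NN2c2ccc(S(N)(=O)=O)cc2)c(OC)c1OC`, is compound 3 with one addition: methoxy in place of hydrogen on an aromatic carbon, turning the 3,4-dimethoxyphenyl into a 2,3,4-trimethoxyphenyl. Going by the values given here, no measured step adds or removes a single methoxy group; the two steps that involve the dimethoxyphenyl, a 2.9-fold higher number from compound 1 to compound 3 (0.46 log units; beyond the scatter) and no change at the digits printed from compound 2 to compound 3 (within the scatter), swap the whole group on the saturated ring carbon and produced at most a modest rise in this assay. Nothing here points to a clear shift in either direction, so the expected step of no change at the digits printed from compound 3 to compound 4 (within the scatter) is one that stays within the scatter.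

On that basis compound 4 is estimated to give 100000 nM, with a plausible range from 40000 nM to 200000 nM.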

Compound 4, concentration for total growth inhibition: 100000 nM
The estimate for compound 4 equals the measured number at the digits printed, within the range that was stated.
By their numbers in this assay, from the lowest: compound 1; then compounds 2, 3 and 4 (each within the scatter of the next).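

Going by these compounds alone, this is the first step that changes a single methoxy group: in this assay, methoxy in place of hydrogen on the aromatic carbon ortho to a large group gives no change at the digits printed from compound 3 to compound 4 (within the scatter), so the 2,3,4-trimethoxyphenyl and the 3,4-dimethoxyphenyl cannot be told apart at this position. The new compound also fits the existing picture, with no change at the digits printed from compound 2 to compound 4 (within the scatter) placing it level with the 2-chlorophenyl compound and a 2.9-fold higher number from compound 1 to compound 4 (0.46 log units; beyond the scatter) leaving the 2-hydroxyphenyl compound as the only one with a clearly lower number, by a modest margin. No supporting measurement is available to explain why this added methoxy group leaves the number as it is.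

From the compounds shown here alone, whether an amine or a carboxylic acid in place of this methoxy group would give a number closer to that of compound 1 remains open. Also open, going by these compounds, is whether methoxy on this same kind of aromatic carbon would matter on the 2-hydroxyphenyl ring of compound 1, whose number does not sit with the other three.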